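Adding a second chlorine to the urea phenyl ring

This account rests on a few compounds, and the source may have more. Where it says the series, first, only, none or still open, it means among the compounds named here.

Three closely related compounds share one core and differ only in the substituted phenyl ring at the far end of the urea. Compound 1 `CN(C)CCCNc1nc(-c2ccc(NC(=O)Nc3ccccc3F)cc2)nc2ccsc12` gives 470 nM in a functional assay on HT-29 cells (Homo sapiens) for cytotoxicity, read by MTT assay, with a stated time of 72 h; a lower number here means a stronger inhibitor, a higher number a weaker inhibitor. Compound 2 `CN(C)CCCNc1nc(-c2ccc(NC(=O)Nc3ccccc3Cl)cc2)nc2ccsc12` gives 390 nM in the same assay, and compound 3 `CN(C)CCCNc1nc(-c2ccc(NC(=O)Nc3ccc(Cl)cc3)cc2)nc2c(Cl)c(Cl)sc12` gives 330 nM. Compound 2 thus sits in the middle of the three, though all three numbers fall within the usual scatter of one another, so no ordering can be read from them.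

The unmeasured compound 4 `CN(C)CCCNc1nc(-c2ccc(NC(=O)Nc3ccc(Cl)cc3Cl)cc2)nc2ccsc12` differs from compound 2 by a single change: chloro in place of hydrogen on an aromatic carbon. In the printed words, the new chloro sits meta to a chloro group and para to a large group, turning the 2-chlorophenyl into a 2,4-dichlorophenyl.

Within the data shown here, the only directly comparable step is the halogen swap on the same ring, a 1.2-fold lower number from compound 1 to compound 2 (0.08 log units; within the scatter), which changed nothing beyond the scatter. Compound 3, which carries a chlorine in the other ring position but also two extra chlorines on the core, gives a number close to that of compound 2, so there is no sign that chlorine on this ring moves the readout much.

For compound 4 the expectation is therefore a step of about a 1.1-fold lower number from compound 2 to compound 4 (0.05 log units; within the scatter), essentially no change beyond scatter. Compound 4 is estimated at 350 nM, within a range of 150 nM to 800 nM.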

Compound 4, half-maximal inhibitory concentration: 1860 nM
Compound 4: the middle estimate sits 5.3-fold (0.73 log units) below what was measured, outside the stated range (above it).
By their numbers in this assay, from the lowest: compounds 3, 2 and 1 (each within the scatter of the next); then compound 4.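

Placing a chloro group on the 2-chlorophenyl ring, para to a large group and meta to the existing chloro, is the first change here to move the number beyond the scatter. In this assay the move to a 2,4-dichlorophenyl ring gives a modest loss of strength (a 4.8-fold higher number from compound 2 to compound 4 (0.68 log units; beyond the scatter)), and the comparison with the 2-fluorophenyl ring points the same way (a 4.0-fold higher number from compound 1 to compound 4 (0.60 log units; beyond the scatter)), whereas the swap of fluoro for chloro stayed within the scatter (a 1.2-fold lower number from compound 1 to compound 2 (0.08 log units; within the scatter)). So the ring accepted one halogen in place of the other, yet the number rose once a second chlorine was added, and no measurement shown here explains why.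

As far as these compounds go, it remains open whether this rise belongs to chlorine itself or would follow any group at this place, such as a methyl, a methoxy or an amine. Also open, from the compounds shown here alone, is how a 4-chlorophenyl ring without the 2-chloro would read on the core of compound 2, which would show whether the added chloro matters alone or only together with the first.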